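The source may hold more compounds than are shown below. What is called first, only, known or untested is meant among the compounds shown, and "the series" means these compounds.

Measured in a functional assay on HeLa cells (Homo sapiens) for inhibition, read by CCK-8 assay, with a stated time of 48 h; a lower number here means a stronger inhibitor, a higher number a weaker inhibitor:
- Compound 1 `COc1ccc(NC(=O)NCCNS(=O)(=O)c2ccc(-c3ccccc3OCc3ccccc3)s2)cc1`: > 50000 nM, a limit of the assay and not a number.
- Compound 2 `O=S(=O)(NCCNC(=S)Nc1cccc(Cl)c1)c1ccc(-c2ccccc2OCc2ccccc2)s1`: 8400 nM
- Compound 3 `O=[N+]([O-])c1cccc(NC(=S)NCCNS(=O)(=O)c2ccc(-c3ccccc3OCc3ccccc3)s2)c1`: 12800 nM

Compound 3 stands level with compound 2, since a 1.5-fold higher number from compound 2 to compound 3 (0.18 log units; within the scatter) lies within the scatter. Swapping nitro for chloro therefore makes no clear difference here. Both of these compounds give a true number, and the gap from the limit of compound 1 is beyond the scatter on each side: an at least 5.9-fold lower number from compound 1 to compound 2 (0.77 log units; beyond the scatter) and an at least 3.9-fold lower number from compound 1 to compound 3 (0.59 log units; beyond the scatter).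

The next compound is compound 4 `Cc1cc(C)cc(NC(=O)NCCNS(=O)(=O)c2ccc(-c3ccccc3OCc3ccccc3)s2)c1`. Its change from compound 3 is a group of 11 heavy atoms (9 carbon, 1 nitrogen, 1 oxygen; one six-membered aromatic ring of carbon only) in place of a group of 12 heavy atoms (7 carbon, 2 nitrogen, 2 oxygen, 1 sulfur; one six-membered aromatic ring of carbon only), on an amine nitrogen. The group entering, (3,5-dimethylphenyl)carbamoyl, holds oxygen and no sulfur, as the matching group in compound 1 does. Compounds 2 and 3 hold sulfur there instead.

For the measured compounds named here, with only three compounds this is a thin pattern, and the dimethyl ring itself has not been tested. Still, compound 1 is the closest measured match, so the gain seen in an at least 3.9-fold lower number from compound 1 to compound 3 (0.59 log units; beyond the scatter) is expected to be largely lost. In this assay, a weaker result is therefore expected, with a real chance of reaching the assay limit. The estimated change is a 3.1-fold higher number from compound 3 to compound 4 (0.49 log units; beyond the scatter). For compound 4 the expected value is 40000 nM, with an estimated range of 15000 nM to 80000 nM.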

Compound 4, half-maximal inhibitory concentration: > 50000 nM
Compound 4: only a limit was reported; the forecaster's own chance of this, stated with the estimate: 55%; at least 1.2-fold (0.09 log units) between middle value and limit.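

Compound 4 gives > 50000 nM, a limit of the assay and not a number. Its (3,5-dimethylphenyl)carbamoyl group, which holds oxygen and no sulfur, stands clearly behind both sulfur-bearing compounds, with an at least 3.9-fold higher number from compound 3 to compound 4 (0.59 log units; beyond the scatter) and an at least 5.9-fold higher number from compound 2 to compound 4 (0.77 log units; beyond the scatter). Oxygen in this group now goes with the limit on two different aromatic rings and sulfur goes with a true number on two others, a pattern that no compound shown goes against, although the step between compound 1 and compound 4 cannot be read: the limit of > 50000 nM in this assay, at which 2 of the 4 values shown sit.

Whether sulfur itself matters stays open, for no pair shown carries the same aromatic ring with both oxygen and sulfur, so the swap of that one atom and the change of ring substituents cannot be told apart. Also open, on these data alone, is what an amine or a carboxylic acid on the aromatic ring would do, or a longer chain on the amine nitrogen.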